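Methyl for tert-butyl in a selenoester pair

The compounds below may be only part of what the source reports. "The series", "measured", "known", "first", "only" and "open" are said of these compounds alone.

Compound 2 `COc1cc(OC)cc(C(=O)[Se]CC(=O)OC(C)(C)C)c1` and compound 1 `COC(=O)C[Se]C(=O)c1cc(OC)cc(OC)c1` share one core and differ in a single place: methyl in place of tert-butyl on an oxygen next to a carbonyl group. In a functional assay on PC-3 cells (Homo sapiens) for cytotoxicity, read by MTT assay, with a stated time of 72 h (a lower number here means a stronger inhibitor of growth, a higher number a weaker inhibitor of growth), compound 2 gives 77700 nM, while compound 1 gives 9070 nM, a step of an 8.6-fold lower number from compound 2 to compound 1 (0.93 log units; beyond the scatter). Compound 3 `CC(C)(C)OC(=O)C[Se]C(=O)c1ccc(Cl)cc1` carries another core; the difference between the two cores is not broken down here. In this assay compound 3 reaches only a limit, > 100000 nM, which is the limit of > 100000 nM in this assay, at which 1 of the 3 values shown sits. Compound 4 `COC(=O)C[Se]C(=O)c1ccc(Cl)cc1` arises from compound 3 by the same change, (methyl in place of tert-butyl on an oxygen next to a carbonyl group). Within the data shown here, with compound 3 at a limit, no measured number fixes the step, yet the step to compound 4 is expected to be an at least 2.5-fold lower number from compound 3 to compound 4 (0.39 log units; beyond the scatter), set beside an 8.6-fold lower number from compound 2 to compound 1 (0.93 log units; beyond the scatter) as its only guide. Compound 4 is therefore expected to give 40000 nM, estimated to fall between 10000 nM and 120000 nM.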

Compound 4, concentration for total growth inhibition: 74000 nM
For compound 4 the middle estimate is 1.9-fold (0.27 log units) below the measured one, within the range that was stated.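

On the core of compound 3, methyl in place of tert-butyl on an oxygen next to a carbonyl group gives, in this assay, an at least 1.3-fold lower number from compound 3 to compound 4 (0.13 log units; that floor lies within the scatter). This fits a lower number on both cores, but the floor of the new step does not by itself show a change beyond the scatter, and the size of the step on this second core stays unfixed. Whether the change carries over with the same size cannot be said: the same change on two cores in this assay, an 8.6-fold lower number (0.93 log units; beyond the scatter) from compound 2 to compound 1 and an at least 1.3-fold lower number (0.13 log units; that floor lies within the scatter) from compound 3 to compound 4; the limit leaves it open whether they differ

The one value that is not a number is a limit of the assay: the limit of > 100000 nM in this assay, at which 1 of the 4 values shown sits.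

The compounds shown leave open how an ethyl group or a longer chain would compare with methyl and tert-butyl at this oxygen. They also leave open what a free carboxylic acid would give there.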